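This account rests on a few compounds, and the source may have more. Where it says the series, first, only, none or still open, it means among the compounds named here.

In an ADME assay on cells (spleen, Mus musculus, strain C57BL/6) for inhibition, read by flow cytometry and propidium iodide staining, with a stated time of 24 h, at 37 degrees C (a lower number here means that less compound is needed, a higher number that more compound is needed for the effect), the measured compounds read:
compound 1 `O=C(Cn1cc(CCCCO)nn1)NCc1ccccc1` gives 1700 uM
compound 2 `O=C(O)CCCCc1cn(CC(=O)NCc2ccccc2)nn1` gives 1080 uM
compound 3 `Nc1cccc(-c2cn(CC(=O)NCc3ccccc3)nn2)c1` gives 800 uM

Compound 3 stands within the scatter of compound 2, as a 1.4-fold lower number from compound 2 to compound 3 (0.13 log units; within the scatter) shows. For the measured compounds named here, its only step beyond the scatter is modest, namely a 2.1-fold lower number from compound 1 to compound 3 (0.33 log units; beyond the scatter) in this series. Compound 4 `Nc1ccc(-c2cn(CC(=O)NCc3ccccc3)nn2)cc1` carries 4-aminophenyl in place of 3-aminophenyl on an aromatic carbon, with 4-aminophenyl in place of 3-aminophenyl on an aromatic carbon as the counted difference. Going by the values given here, no measured step moves the amino group. The steps above replace a whole chain at that carbon, and even those stay small, so no step beyond the scatter is expected in this assay here. The expected step is no change at the digits printed from compound 3 to compound 4 (within the scatter) for this change. The estimate for compound 4 is 800 uM within a range of 450 uM to 1400 uM as expected bounds.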

Compound 4, concentration for half-maximal effect: 1240 uM
Estimate against measurement, compound 4: 1.6-fold (0.19 log units) below; the measured number falls inside the stated range.
By their numbers in this assay, from the lowest: compounds 3, 2, 4 and 1 (each within the scatter of the next, the first and the last beyond it).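

Moving the amino group, with 4-aminophenyl in place of 3-aminophenyl on the aromatic carbon, gives a 1.6-fold higher number from compound 3 to compound 4 (0.19 log units; within the scatter) in this assay and so leaves the number within the scatter. Against the chains, 4-aminophenyl gives a 1.1-fold higher number from compound 2 to compound 4 (0.06 log units; within the scatter) and a 1.4-fold lower number from compound 1 to compound 4 (0.14 log units; within the scatter) so the one step beyond the scatter, seen with 3-aminophenyl against 4-hydroxybutyl, has no counterpart with 4-aminophenyl. No measurement on hand bears on these numbers.

Open, going by these compounds, is whether a carboxylic acid or a hydroxy group on the phenyl ring, in place of the amine, would read differently in this assay.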